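Working notes on three measured analogues and a fourth

The source may hold more compounds than are shown below. What is called first, only, known or untested is meant among the compounds shown, and "the series" means these compounds.

Measured so far:
compound 1, `COc1cc(C)cc(-c2c(-c3ccnc(-c4ccc(C(C)=O)cc4)c3)cnn2CC#N)c1`, 19%
compound 2, `COc1cc(C)cc(-c2nn(CC#N)cc2-c2ccc(-c3cccc(C(C)=O)c3)nc2)c1`, 17%
compound 3, `Cc1cc(O)cc(-c2nn(CC#N)cc2-c2ccnc(-c3ccc(N(C)C)cc3)c2)c1`, 24%

In a functional assay on NCI-H23 cells (Homo sapiens) for cytotoxicity, read by sulforhodamine B assay, with a stated time of 48 h, tested at 1 uM (a lower number here means a stronger effect, a higher number a weaker effect of the compound at the concentration tested), compound 1 gives 19%. In this assay compound 2 gives 17%, and compound 3 gives 24%. Compound 1 is the second highest of the three numbers; the nearest is compound 2, whose number is lower by an amount within the scatter, and the furthest is compound 3, whose number is higher by an amount that is also within the scatter. The three values thus do not separate from one another, and none of the three can be called stronger or weaker than the others.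

For the measured compounds named here, no pair of measured compounds differs in one place only, so no single step is available from the measured set. Compound 4, `COc1cc(C)cc(-c2c(-c3ccnc(-c4ccc(N(C)C)cc4)c3)cnn2CC#N)c1`, has not been measured. Its difference from compound 1 is dimethylamino in place of acetyl on an aromatic carbon. Going by the values given here, compound 3 also carries a dimethylamino on an aromatic carbon, but it differs from compound 1 in a second place as well, so its value shows only that a compound of this kind sits within the scatter of compound 1.

The expected step is a number 3 percentage points higher from compound 1 to compound 4 (within the scatter), which is none beyond the scatter. Compound 4 is estimated at 22%, with a range from 10% to 36%.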

Compound 4, a percentage reported as activity, at one concentration (the size of the read-out at that concentration, not a potency): 17%
The estimate for compound 4 lay 5 percentage points above the measured number; measured number inside the range.
By their numbers in this assay, from the lowest: compounds 2, 4, 1 and 3 (each within the scatter of the next).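

In this assay, for the compounds shown here, the exchange of acetyl for dimethylamino on an aromatic carbon of a six-membered aromatic ring of carbon only, para to a large group, gives a number 2 percentage points lower from compound 1 to compound 4 (within the scatter), the first change that can be read in one place alone. The 4-acetylphenyl and 4-(dimethylamino)phenyl forms therefore do not separate at the concentration tested, a result compound 3 could not give, since it differs from compound 1 in a second place as well. Nothing at hand bears on why these two groups give numbers within the scatter of each other.

On these data alone, whether any group at this position can move the number beyond the scatter remains open, and a carboxylic acid or a longer chain ending in an amine would be a further test of it, set on the same 4-substituted phenyl with the rest of compound 1 unchanged. As far as these compounds go, the read-out gives the size of the effect at one concentration and not a potency, so whether compound 1 and compound 4 would also stay together at lower concentrations also remains open.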